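Replacing the tetrahydroisoquinoline on compound 1

This account rests on a few compounds, and the source may have more. Where it says the series, first, only, none or still open, it means among the compounds named here.

In a functional assay on HL-60 cells (Homo sapiens) for cytotoxicity, read by MTT assay, with a stated time of 72 h (a higher number here means a weaker inhibitor, a lower number a stronger inhibitor), compound 1 `Cc1ccc(S(=O)(=O)c2nc3ccccc3nc2N2CCc3ccccc3C2)cc1` gives 3610 nM and compound 2 `O=S(=O)(c1ccc(Br)cc1)c1nc2ccccc2nc1N1CCc2ccccc2C1` gives 2610 nM, so the two stand within the scatter of each other. For the measured compounds named here, the one measured step, a 1.4-fold lower number from compound 1 to compound 2 (0.14 log units; within the scatter), is bromo in place of methyl on an aromatic carbon and leaves the 1,2,3,4-tetrahydroisoquinolin-2-yl group untouched. It therefore says little about compound 3 `Cc1ccc(S(=O)(=O)c2nc3ccccc3nc2N2CCCC(O)C2)cc1`, which carries 3-hydroxypiperidin-1-yl in place of that group: 3-hydroxypiperidin-1-yl in place of 1,2,3,4-tetrahydroisoquinolin-2-yl on an aromatic carbon. Going by the values given here, no measured step covers this exchange, so any forecast is loose and its range wide. A moderate move towards a higher number in this assay is expected, though a step within the scatter cannot be excluded. The estimated change is a 1.7-fold higher number from compound 1 to compound 3 (0.22 log units; within the scatter). For compound 3 the expected value is 6000 nM, with an estimated range from 2000 nM to 18000 nM.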

Compound 3, half-maximal inhibitory concentration: 6080 nM
For compound 3 the middle estimate is 1.0-fold (0.01 log units) below the measured one; low and high end bracket the measured number.
By their numbers in this assay, from the lowest: compounds 2, 1 and 3 (each within the scatter of the next, the first and the last beyond it).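

Compounds 1 and 2 share the 1,2,3,4-tetrahydroisoquinolin-2-yl group, so the position next to the ring nitrogen had no reading until this exchange. In this assay, putting 3-hydroxypiperidin-1-yl in place of that group gives a 1.7-fold higher number from compound 1 to compound 3 (0.23 log units; within the scatter), so on this single step the read-out stays within the scatter although the six-membered aromatic ring of carbon only leaves and a hydroxy group enters. Nothing measured here bears on the reason for this outcome.

Still open, as far as these compounds go, is how the loss of the aromatic ring and the entry of the hydroxy group each count, which a plain piperidin-1-yl group at this position would help separate. Also open, from the compounds shown here alone, is how a morpholin-4-yl or piperazin-1-yl group would read here.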